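A few compounds are considered here, and "the series" means these few. Any claim that something is new, unique, unknown or untested is made for them only; others in the source may bear on it.

Measured compounds:
compound 1 `O=C(CN1CCN(c2ccccc2F)CC1)Nc1ccc(C(=O)/C=C/c2cn(Cc3ccc(Br)cc3)nn2)cc1` — 11300 nM
compound 2 `COc1ccccc1N1CCN(CC(=O)Nc2ccc(C(=O)/C=C/c3cn(Cc4ccc(Br)cc4)nn3)cc2)CC1` — 36800 nM

In a functional assay on MCF7 cells (Homo sapiens) for inhibition, read by MTT assay (a higher number here means a weaker inhibitor, a lower number a stronger inhibitor), compound 2 gives 36800 nM, the higher of the two numbers; compound 1 gives 11300 nM. Among the compounds with values here, the only measured step, a 3.3-fold higher number from compound 1 to compound 2 (0.51 log units; beyond the scatter), is the single comparison available. Compound 3 `O=C(CN1CCN(c2ccccc2)CC1)Nc1ccc(C(=O)/C=C/c2cn(Cc3ccc(Br)cc3)nn2)cc1` differs from compound 2 by hydrogen in place of methoxy on an aromatic carbon. Within the data shown here, no measured step removes a group to hydrogen, so that step bears only indirectly; it does show that the group on this carbon matters beyond the scatter. The change is expected to give a modest lower number, a 2.5-fold lower number from compound 2 to compound 3 (0.39 log units; beyond the scatter). Compound 3 is estimated at 15000 nM, with a range of 5000 nM to 45000 nM.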

Compound 3, half-maximal inhibitory concentration: 49200 nM
Estimate against measurement, compound 3: 3.3-fold (0.52 log units) below, outside the stated range (above it).
By their numbers in this assay, from the lowest: compound 1; then compounds 2 and 3 (each within the scatter of the next).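

Hydrogen in place of methoxy on this aromatic carbon leaves the number in this assay within the scatter (a 1.3-fold higher number from compound 2 to compound 3 (0.13 log units; within the scatter)), so 2-methoxyphenyl and phenyl are not told apart here. Hydrogen in place of fluoro gives a step beyond the scatter (a 4.4-fold higher number from compound 1 to compound 3 (0.64 log units; beyond the scatter)), which makes compound 1 the strongest of the three and sets fluoro apart from both methoxy and hydrogen. No evidence at hand accounts for this.

Open, going by these compounds, is how an amine or a chloro group on this carbon would read, and whether fluoro alone holds this advantage.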